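Changing the aryl group of compound 1

This account rests on a few compounds, and the source may have more. Where it says the series, first, only, none or still open, it means among the compounds named here.

In a functional assay on MCF7 cells (Homo sapiens) for cytotoxicity, read by MTT assay, with a stated time of 72 h (a higher number here means a weaker inhibitor, a lower number a stronger inhibitor), compound 1 `COc1ccc(/C=C/C(=O)Nc2cc3c(Nc4ccc(F)c(Cl)c4)ncnc3cc2O[C@H]2CCOC2)c(OC)c1` gives 28600 nM. Compound 2 `COc1cc2ncnc(Nc3ccc(F)c(Cl)c3)c2cc1NC(=O)/C=C/c1ccccc1[N+](=O)[O-]` gives 36500 nM and compound 3 `COc1ccc(/C=C/C(=O)Nc2cc3c(Nc4ccc(F)c(Cl)c4)ncnc3cc2OC)c(OC)c1` gives 36600 nM, so compound 1 stands within the scatter of both. Compound 4 `O=C(/C=C/c1cc(Br)c(O)c(Br)c1)Nc1cc2c(Nc3ccc(F)c(Cl)c3)ncnc2cc1O[C@H]1CCOC1` has not yet been measured. It differs from compound 1 in one place: 3,5-dibromo-4-hydroxyphenyl in place of 2,4-dimethoxyphenyl on a double-bonded chain carbon bound to a double-bonded chain carbon. In words, 3,5-dibromo-4-hydroxyphenyl stands in place of 2,4-dimethoxyphenyl on a double-bonded chain carbon bound to a double-bonded chain carbon.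

Within the data shown here, two measured steps bear on this. An exchange at the same place, 2,4-dimethoxyphenyl in place of 2-nitrophenyl, gave a 1.0-fold higher number from compound 2 to compound 3 (0.00 log units; within the scatter). Methyl in place of oxolan-3-yl, on an oxygen on an aromatic ring, gave a 1.3-fold higher number from compound 1 to compound 3 (0.11 log units; within the scatter). Among the measured compounds shown here, no measured compound carries the entering group, so the range must stay wide. In this assay, no step beyond the scatter is expected, in either direction. The expected step is a 1.2-fold lower number from compound 1 to compound 4 (0.08 log units; within the scatter). For compound 4 the estimate is 24000 nM, with an expected range from 7000 nM to 60000 nM.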

Compound 4, half-maximal inhibitory concentration: 30600 nM
Compound 4: middle estimate off by 1.3-fold (0.11 log units), on the low side; the measured number falls inside the stated range.
By their numbers in this assay, from the lowest: compounds 1, 4, 2 and 3 (each within the scatter of the next).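

Compound 4 replaces 2,4-dimethoxyphenyl with 3,5-dibromo-4-hydroxyphenyl on a double-bonded chain carbon bound to a double-bonded chain carbon, and in this assay this gives a 1.1-fold higher number from compound 1 to compound 4 (0.03 log units; within the scatter). The earlier step at this place exchanged one aryl group for another on the methyl ether. This one shows that, with the oxolan-3-yl group kept, the number also stays within the scatter when the aryl group takes on bromine and a hydrogen-bond donor and loses both methoxy groups. No measurement here explains this insensitivity to the aryl group.

What the compounds shown leave open is whether any group at this place can carry the number beyond the scatter in this assay. An aryl group bearing an amine or a carboxylic acid, or a longer chain carrying the aryl group, would test this.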